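Chain extension from compound 2 to compound 3

The source may report more compounds than this note shows. Statements on the series, on what has been measured and on what is new or still open speak of the compounds shown alone.

In a functional assay, with a stated time of 10 min (on this read-out higher numbers stand for weaker inhibition and lower numbers for stronger inhibition), compound 1 (`CCCCCCOc1cc(OC)c(Br)cc1C(C)=O`) gives 53100000 nM and compound 2 (`CCCCCCCCCCOc1cc(OC)c(Br)cc1C(C)=O`) gives 29700000 nM. These two numbers lie within the scatter of each other, so compound 2 stands level with compound 1 and no order can be read between them.

Compound 3 (`CCCCCCCCCCCCOc1cc(OC)c(Br)cc1C(C)=O`) keeps the shared core and differs from compound 2 as follows: ethyl in place of hydrogen on a saturated chain carbon, ten or more bonds along the chain from an oxygen on an aromatic ring. For the measured compounds named here, one measured step bears on this change, a lengthening of the same chain: butyl in place of hydrogen on a saturated chain carbon, six bonds along the chain from an oxygen on an aromatic ring. That single step gives no trend with chain length, and the data do not show whether a further extension would behave alike.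

Going by the values given here, with a 1.8-fold lower number from compound 1 to compound 2 (0.25 log units; within the scatter) as the only guide, no step beyond the scatter is expected in this assay, and no direction is firmly expected. The expected step is a 1.2-fold lower number from compound 2 to compound 3 (0.07 log units; within the scatter). The estimated value for compound 3 is 25000000 nM, with an expected range from 12000000 nM to 55000000 nM.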

Compound 3, half-maximal inhibitory concentration: 23100000 nM
Estimate against measurement, compound 3: 1.1-fold (0.03 log units) above; low and high end bracket the measured number.
By their numbers in this assay, from the lowest: compounds 3, 2 and 1 (each within the scatter of the next, the first and the last beyond it).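

In this assay, ethyl in place of hydrogen on a saturated chain carbon, ten or more bonds along the chain from an oxygen on an aromatic ring, gives a 1.3-fold lower number from compound 2 to compound 3 (0.11 log units; within the scatter) and so leaves compound 3 level with compound 2. For the compounds shown here, the hexyl change, six bonds along the chain from the same oxygen, gives a 2.3-fold lower number from compound 1 to compound 3 (0.36 log units; beyond the scatter) and is the first difference in these compounds to lie beyond the scatter, though it is modest and appears only between the two ends of the set, while each shorter step stays within the scatter. No measurement shown here accounts for this difference.

Three compounds cannot establish whether a longer chain would widen this difference or leave the number level with compound 3. From the compounds shown here alone, it also remains open whether an amine or a carboxylic acid at the far end of the chain would give a step beyond the scatter from compound 3 in this read-out.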